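Adding a Bromo Group to Compound 2

The source may hold more compounds than are shown below. What is called first, only, known or untested is meant among the compounds shown, and "the series" means these compounds.

Of the compounds shown here, two have numbers so far in a functional assay on KB cells (Homo sapiens) for cytotoxicity; on this read-out higher numbers stand for an effect only at larger amounts of compound and lower numbers for an effect already at smaller amounts. Compound 1 `COC1=C(C)C(=O)/C(=C(O)/C=C/c2ccc(C)cc2)C(=O)C1(C)C` gives 1.9 ug/mL, and compound 2 `CCCC1=C(OC)C(CCC)(CCC)C(=O)/C(=C(O)\C=C\c2ccccc2)C1=O` gives 0.8 ug/mL. Compound 2 therefore holds the lower of the two numbers, and its gap to compound 1 is larger than the usual scatter between repeated measurements. These two compounds differ in more than one place, so the gap cannot be pinned on any single group.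

The unmeasured compound 3 `CCCC1=C(OC)C(CCC)(CCC)C(=O)/C(=C(O)\C=C\c2ccc(Br)cc2)C1=O` matches compound 2 except for one change: bromo in place of hydrogen on an aromatic carbon. A bromo stands in place of a hydrogen on an aromatic carbon, para to a large group, which turns the phenyl into a 4-bromophenyl. Among the measured compounds shown here, no measured pair shows what a single change of this kind does here, so the expectation stays cautious, with no clear direction and no shift beyond the scatter. In this assay the expected step is a 1.1-fold lower number from compound 2 to compound 3 (0.06 log units; within the scatter). For compound 3 the estimated value is 0.7 ug/mL, with an expected range of 0.25 ug/mL to 2 ug/mL.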

Compound 3, concentration for half-maximal effect: 0.9 ug/mL
For compound 3 the middle estimate is 1.3-fold (0.11 log units) below the measured one; the range from low to high includes it.
By their numbers in this assay, from the lowest: compounds 2 and 3 (each within the scatter of the next); then compound 1.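

In this assay, among the compounds shown here, this is the first comparison in which only one place differs, and the result is a 1.1-fold higher number from compound 2 to compound 3 (0.05 log units; within the scatter). At this position, para to a large group, a bromo in place of hydrogen therefore produces no shift that can be told apart from the ordinary spread of repeated measurements, so turning the phenyl into a 4-bromophenyl leaves cytotoxicity on KB cells in the same range. Nothing available here says what lies behind this flat result, so it stands as an observation about a single pair, without an explanation.

As far as these compounds go, whether this tolerance belongs to the position in general or only to bromo remains open, as a group of a quite different kind on the same aromatic carbon, such as an amine or a carboxylic acid, could give a different step. Also unsettled is which of the several differences between compound 1 and compound 2 accounts for the gap between their numbers, and whether a bromo on the aromatic ring of compound 1 would likewise leave its number in place.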